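The source may report more compounds than this note shows. Statements on the series, on what has been measured and on what is new or still open speak of the compounds shown alone.

Working notes on a small set of compounds built on one shared core.

Compound 1 `COc1cc(O)c(C(=O)/C=C/c2ccc(F)cc2)c(OC)c1` is reported in a functional assay on MDA-MB-231 cells (Homo sapiens), read by fluorescence and BrdU incorporation, with a stated time of 48 h, tested at 10 uM (a lower number here means a stronger effect, a higher number a weaker effect of the compound at the concentration tested), as "not active" (no number reported), with no number attached. Compound 2 `COc1cccc(/C=C/C(=O)c2c(OC)cc(OC)cc2OC)c1` gives 43% in this assay, and compound 3 `COc1cc(OC)c(C(=O)/C=C/c2ccc(Cl)cc2)c(OC)c1` gives 39%. Compound 3 therefore carries the lower of the two numbers available, but the step of a number 4 percentage points lower from compound 2 to compound 3 (within the scatter) lies within the scatter, so no order between compound 2 and compound 3 can be read from it, and compound 1 contributes no number to compare against.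

Compound 4 `COc1cc(OC)c(C(=O)/C=C/c2ccc(Br)cc2)c(OC)c1` remains to be measured in this assay. It differs from compound 3 by bromo in place of chloro on an aromatic carbon; read one bond further out, 4-chlorophenyl becomes 4-bromophenyl. Among the compounds with values here, no measured step addresses an exchange of one halogen for another on that ring. Within the data shown here, the only step at hand, a number 4 percentage points lower from compound 2 to compound 3 (within the scatter), replaced a different group on that ring and stayed within the scatter, so it offers no direction for the present change. The counted difference is one heavy atom for one heavy atom, with no change in donors, acceptors, rings or charge, and the expected step is a number 1 percentage points lower from compound 3 to compound 4 (within the scatter), that is, nothing beyond the scatter. Compound 4 is accordingly estimated at 38% in this assay, with a range from 25% to 52%.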

Compound 4, a percentage reported as activity, at one concentration (the size of the read-out at that concentration, not a potency): 42%
The estimate for compound 4 lay 4 percentage points below the measured number; the measured number falls inside the stated range.
By their numbers in this assay, from the lowest: compounds 3, 4 and 2 (each within the scatter of the next).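

In this assay, within the data shown here, bromo in place of chloro on an aromatic carbon, para to a large group, gives a number 3 percentage points higher from compound 3 to compound 4 (within the scatter), the only measured exchange of one halogen for another at this place, and it yields no change that can be read. Against the 3-methoxyphenyl of compound 2, 4-bromophenyl gives a number 1 percentage points lower from compound 2 to compound 4 (within the scatter), which matches the earlier a number 4 percentage points lower from compound 2 to compound 3 (within the scatter): neither halogen-bearing ring can be told apart from the methoxy-bearing ring in this read-out, and compounds 2, 3 and 4 form a single group with no order among them. No evidence at hand bears on this result.

Compound 1 has no number and differs from compound 3 in more than one place, carrying both a fluoro group and a hydroxy group, so neither fluoro at this position nor hydroxy on the shared core can be judged on its own. Going by these compounds, it also remains open whether a group of another kind at this position, such as an amine, a carboxylic acid or a longer chain, would move the number beyond the scatter.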